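A few compounds are considered here, and "the series" means these few. Any claim that something is new, unique, unknown or untested is made for them only; others in the source may bear on it.

In an assay on isolated protein (strain Sprague-Dawley) for inhibition of Amine oxidase [flavin-containing] A (Rattus norvegicus), read by spectrophotometry, with a stated time of 5 min, tested at 10 uM (on this read-out lower numbers stand for less inhibition and higher numbers for more inhibition at the one concentration tested (going by the name of the read-out)), compound 1 `CCOc1cc(=O)oc2cc(OCc3cccc(Cl)c3)ccc12` gives 2%, the second highest of the three numbers measured. Compound 3 `O=C(O)COc1cc(=O)oc2cc(OCc3cccc(Cl)c3)ccc12` gives 0%, and the step of a number 2 percentage points lower from compound 1 to compound 3 (within the scatter) accompanies carboxy in place of methyl on a saturated chain carbon bound to an oxygen on an aromatic ring. Among the compounds with values here, compound 2 `COc1cc(=O)oc2cc(OCc3cccc(Br)c3)ccc12` gives 27%; it differs from compound 1 in more than one place, so no single step is drawn from it. Compound 4 `CCNC(=O)Nc1cc(=O)oc2cc(OCc3cccc(Cl)c3)ccc12` carries (ethylcarbamoyl)amino in place of ethoxy on an aromatic carbon. Within the data shown here, only the step from compound 1 to compound 3 bears on this change, and it lies within the scatter, so no step beyond the scatter is expected in this assay. Compound 4 is therefore estimated at 8% (range 0% to 30%). The expected step is a number 6 percentage points higher from compound 1 to compound 4 (within the scatter).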

Compound 4, a percentage reported as inhibition, at one concentration (the size of the read-out at that concentration, not a potency): 0%
Compound 4: middle estimate off by 8 percentage points, on the high side; low and high end bracket the measured number.
By their numbers in this assay, from the lowest: compounds 3, 4 and 1 (each within the scatter of the next); then compound 2.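

At this position, opposite the ring oxygen, this assay gives a number 2 percentage points lower from compound 1 to compound 4 (within the scatter), with the nitrogen-linked (ethylcarbamoyl)amino group, with its hydrogen-bond donors, in place of ethoxy. Against the carboxymethoxy group, the same group gives no change at the digits printed from compound 3 to compound 4 (within the scatter), so neither replacement of ethoxy moves the number beyond the scatter. No measured evidence accounts for this.

With compound 1 at 2%, these steps start close to zero and cannot show whether any group here could raise inhibition. As far as these compounds go, how a plain amine or a longer alkoxy chain at this position would read on the core of compound 1 remains open.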